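Replacing the aryl amide of compound 3 with a carbamate

A few compounds are considered here, and "the series" means these few. Any claim that something is new, unique, unknown or untested is made for them only; others in the source may bear on it.

Measured compounds:
Compound 1 `O=C(c1ccccc1C(F)(F)F)N(/N=N/c1ccc([N+](=O)[O-])cc1Br)c1ccc([N+](=O)[O-])cc1Br`: 13300 nM
Compound 2 `O=C(c1ccccc1F)N(/N=N/c1ccc([N+](=O)[O-])cc1Cl)c1ccc([N+](=O)[O-])cc1Cl`: 2350 nM
Compound 3 `O=C(c1cccc(C(F)(F)F)c1)N(/N=N/c1ccc([N+](=O)[O-])cc1Cl)c1ccc([N+](=O)[O-])cc1Cl`: 1180 nM

In a functional assay on HeLa cells (Homo sapiens) for cytotoxicity, read by MTT assay, with a stated time of 72 h (on this read-out higher numbers stand for weaker inhibition and lower numbers for stronger inhibition), compound 3 stands at the lowest of the three numbers. Its nearest neighbour is compound 2, and the difference between them, a 2.0-fold lower number from compound 2 to compound 3 (0.30 log units; within the scatter), lies within the scatter, so the two cannot be ranked against each other. Compound 1 sits well apart, with a number beyond the scatter above that of compound 3.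

Compound 4 `COC(=O)N(/N=N/c1ccc([N+](=O)[O-])cc1Cl)c1ccc([N+](=O)[O-])cc1Cl` is the next compound to be measured in this assay. It differs from compound 3 in one place: methoxy in place of 3-(trifluoromethyl)phenyl on a carbonyl carbon. Going by the values given here, the only measured step available, a 2.0-fold lower number from compound 2 to compound 3 (0.30 log units; within the scatter), exchanges one aromatic group for another on the same carbonyl carbon and changes nothing beyond the scatter. Among the compounds with values here, it does not address the removal of an aromatic ring in favour of a small methoxy group, so no measured step bears directly on this change. The shared core with its two nitro-bearing chloro-aryl groups is kept intact in compound 4.

Given that absence of direct guidance, compound 4 is expected to show a modest step of a 2.5-fold higher number from compound 3 to compound 4 (0.41 log units; beyond the scatter), and its estimated value in this assay is 3000 nM, within a range from 800 nM to 12000 nM.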

Compound 4, half-maximal inhibitory concentration: 980 nM
For compound 4 the middle estimate is 3.1-fold (0.49 log units) above the measured one; the range from low to high includes it.
By their numbers in this assay, from the lowest: compounds 4, 3 and 2 (each within the scatter of the next, the first and the last beyond it); then compound 1.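

In this assay, the step of a 1.2-fold lower number from compound 3 to compound 4 (0.08 log units; within the scatter) shows that, on this carbonyl carbon bonded to the amide-type nitrogen, the large 3-(trifluoromethyl)phenyl group can give way to methoxy without a change that can be read. Going by these compounds alone, the earlier compounds had only exchanged one aromatic group for another here, so this is the first sign that, for these compounds in this read-out, an aromatic ring at this place is not required for a value in this range. The comparison with the other aryl compound, a 2.4-fold lower number from compound 2 to compound 4 (0.38 log units; beyond the scatter), is a modest step beyond the scatter, but since compound 2 and compound 3 cannot be ranked against each other, it gives no firm order among the three groups, and no evidence is available to explain these results.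

On these data alone, it remains open whether an ethoxy group, a longer alkoxy chain or an amine such as dimethylamino on the same carbonyl carbon would keep the value in this range. As far as these compounds go, it is also open whether methoxy would give a similar result with the bromine-bearing aryl groups of compound 1.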